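The source may hold more compounds than are shown below. What is called first, only, known or untested is meant among the compounds shown, and "the series" means these compounds.

Measured so far:
compound 1, `O=C(CN(c1nc(Cl)nc2[nH]cnc12)C1CC1)NCC(=O)OCc1ccccc1`: 27.2%
compound 2, `O=C(CN(c1nc(Cl)nc2[nH]cnc12)C1CC1)N[C@@H](CC(=O)OCc1ccccc1)C(=O)OCc1ccccc1`: 15.6%

In a functional assay on the whole organism (Tail, strain ICR) with Mus musculus as the target, in the tail flick test, with a stated time of 90 min, at a dose of 25 umol/kg by the oral route (a lower number here means a weaker effect, a higher number a stronger effect of the compound at the dose given), compound 1 gives 27.2% and compound 2 gives 15.6%. For the measured compounds named here, compound 2 stands lowest of the two numbers; its only neighbour is compound 1, and the one known step is a number 11.6 percentage points lower from compound 1 to compound 2 (beyond the scatter), a modest fall beyond the scatter. Compound 3, `CSCC[C@H](NC(=O)CN(c1nc(Cl)nc2[nH]cnc12)C1CC1)C(=O)OCc1ccccc1`, has not yet been measured. It differs from compound 2 as (methylsulfanyl)methyl in place of benzyloxycarbonyl on a saturated chain carbon, two bonds along the chain from an amide-type nitrogen and a carbonyl carbon. Going by the values given here, no measured step swaps one side chain for another at this carbon; the single step, a number 11.6 percentage points lower from compound 1 to compound 2 (beyond the scatter), concerns the larger group against hydrogen and bears on the new change only indirectly. With the benzyloxycarbonyl gone, compound 3 is expected to settle somewhere between the two measured numbers. For compound 3 the expected step is a number 5.4 percentage points higher from compound 2 to compound 3 (within the scatter), upward, within or barely beyond the scatter. The value estimated for compound 3 is 21%, with a range from 8% to 34%.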

Compound 3, a percentage reported as activity, at one dose (the size of the read-out at that dose, not a potency): 44.6%
The estimate for compound 3 lay 23.6 percentage points below the measured number; the whole stated range lies below it.
By their numbers in this assay, from the lowest: compound 2; then compound 1; then compound 3.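

In this assay, the side chain on this saturated chain carbon can raise the number as well as lower it: 2-(methylsulfanyl)ethyl in place of hydrogen gives a number 17.4 percentage points higher from compound 1 to compound 3 (beyond the scatter) and so runs opposite to the earlier a number 11.6 percentage points lower from compound 1 to compound 2 (beyond the scatter) for (benzyloxycarbonyl)methyl. Exchanging benzyloxycarbonyl for (methylsulfanyl)methyl gives a number 29 percentage points higher from compound 2 to compound 3 (beyond the scatter) and shows that, among these three compounds, the direction of the step depends on which group is present and not on substitution at this carbon alone. Nothing available accounts for the opposite steps of the two side chains.

On these data alone, whether the sulfur matters remains open, as a propyl chain of carbon only has no number to set against compound 3 at 44.6% in this assay here. Also open, as far as these compounds go, is how a carboxylic acid in place of the benzyloxycarbonyl group would read.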